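Moving One Hydroxyl on a Weak Inhibitor

The compounds below may be only part of what the source reports. "The series", "measured", "known", "first", "only" and "open" are said of these compounds alone.

Compound 1 `Oc1ccc(-c2cc(-c3ccc(C(F)(F)F)cc3)cc(-c3cccc(O)c3)n2)cc1` gives > 50000 nM (a limit, not a number)
Compound 2 `Oc1cccc(-c2cc(-c3ccc(OC(F)(F)F)cc3)cc(-c3ccccc3O)n2)c1` gives 21100 nM (a measured number)

Both results come from a functional assay on DU-145 cells (Homo sapiens) for inhibition (a lower number here means a stronger inhibitor, a higher number a weaker inhibitor), and are read as the half-maximal inhibitory concentration. For the measured compounds named here, compound 2, at 21100 nM here, holds the only exact number so far. Compound 1 reads > 50000 nM here, and that is a limit of the assay.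

Compound 3 `Oc1ccc(-c2cc(-c3ccc(OC(F)(F)F)cc3)cc(-c3cccc(O)c3)n2)cc1` has the same atoms as compound 2, joined differently. The change is 4-hydroxyphenyl in place of 2-hydroxyphenyl on an aromatic carbon in which 4-hydroxyphenyl takes the place of 2-hydroxyphenyl on an aromatic carbon next to the ring nitrogen. Going by the values given here, no pair of measured compounds shows what a change like this does, so its size cannot be read from the data.

In this assay a small shift toward weaker inhibition is expected, perhaps none beyond the scatter, starting from compound 2 at 21100 nM in this assay. The expected change is a 1.4-fold higher number from compound 2 to compound 3 (0.15 log units; within the scatter) as an estimate, and a reading at the limit of the assay remains possible. For compound 3 the estimate is 30000 nM with an expected range from 10000 nM to 60000 nM in this assay.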

Compound 3, half-maximal inhibitory concentration: 18100 nM
For compound 3 the middle estimate is 1.7-fold (0.22 log units) above the measured one, within the range that was stated.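

Swapping 2-hydroxyphenyl for 4-hydroxyphenyl on the aromatic carbon next to the ring nitrogen gives a 1.2-fold lower number from compound 2 to compound 3 (0.07 log units; within the scatter) in this assay, so at this place, moving the hydroxyl around its ring makes no difference that can be told from the scatter. For the compounds shown here, on the other side of the core, trifluoromethoxy in place of trifluoromethyl gives an at least 2.7-fold lower number from compound 1 to compound 3 (0.44 log units; beyond the scatter), which is the first step in this set that lies beyond the scatter. The reading for compound 1 is a limit and not a number, so the true size of that step stays unknown: the limit of > 50000 nM in this assay, at which 1 of the 3 values shown sits.

The compounds shown leave open whether this place needs a hydroxyl at all, since every group there so far is a hydroxyphenyl, and an amine or a carboxylic acid on that ring could behave quite differently. They also leave open whether the gain seen with trifluoromethoxy would hold with 2-hydroxyphenyl at this place, and whether any change here can bring the numbers far below those seen so far.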